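A few compounds are considered here, and "the series" means these few. Any claim that something is new, unique, unknown or untested is made for them only; others in the source may bear on it.

For the measured compounds named here, compound 2 `COc1ccc(F)cc1CNCCCNc1ccnc2cc(Cc3ccc(F)cc3)ccc12` gives 23 10^-6 cm/s in an ADME assay for permeability, using PAMPA, with a stated time of 30 min, at pH 7.4 (on this read-out lower numbers stand for lower permeability and higher numbers for higher permeability), level with compound 3 `COc1cccc(CNCCCNc2ccnc3cc(Cc4ccc(F)cc4)ccc23)c1O`, which gives 23 10^-6 cm/s, and together these are the lowest of the three numbers known; furthest from both stands compound 1 `Fc1ccc(-c2ccc3c(NCCCNCc4ccco4)ccnc3c2)cc1`, which gives 237 10^-6 cm/s. Going by the values given here, the one single-site step known is no change at the digits printed from compound 2 to compound 3 (within the scatter), a change on the saturated chain carbon bound to the amine nitrogen that left the number unchanged. Compound 4 `COc1ccc(F)cc1CNCCCNc1ccnc2cc(-c3cccc4ccccc34)ccc12` differs from compound 2 at another place: naphthalen-1-yl in place of 4-fluorobenzyl on an aromatic carbon. Among the compounds with values here, no measured step covers this change directly. Compound 1 carries an aryl group bound straight to the same aromatic carbon and shows a much higher number than compound 2, but the two also differ at the amine end, so their values alone cannot settle the question. Compound 4 is therefore expected to show a higher number than compound 2, a step of about a 3.5-fold higher number from compound 2 to compound 4 (0.54 log units; beyond the scatter), though with wide uncertainty. For compound 4 the estimate is 80 10^-6 cm/s, ranging from 25 10^-6 cm/s to 250 10^-6 cm/s.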

Compound 4, apparent permeability: 237 10^-6 cm/s
Compound 4: the middle estimate sits 3.0-fold (0.47 log units) below what was measured; the range from low to high includes it.
By their numbers in this assay, from the lowest: compounds 2 and 3 (each within the scatter of the next); then compounds 1 and 4 (each within the scatter of the next).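

In this assay, for the compounds shown here, this aromatic carbon proves to be a site where a single change moves the number strongly: the exchange of 4-fluorobenzyl for naphthalen-1-yl gives a 10-fold higher number from compound 2 to compound 4 (1.01 log units; beyond the scatter), whereas the only earlier single-site step, made at the other end of the molecule, was no change at the digits printed from compound 2 to compound 3 (within the scatter). The entering group has 10 heavy atoms and 2 six-membered aromatic rings of carbon only, against 8 heavy atoms and one such ring in the group it replaces, and neither carries a hydrogen-bond donor, a hydrogen-bond acceptor or a net charge. No measurement at hand accounts for the size of this step.

As far as these compounds go, it remains open whether a phenyl or a pyridyl group on the same carbon would give a similar number. Also open, from the compounds shown here alone, is whether naphthalen-1-yl would give a step of this size with the 2-hydroxy-3-methoxyphenyl group of compound 3 in place.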